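The compounds below may be only part of what the source reports. "The series", "measured", "known", "first", "only" and "open" are said of these compounds alone.

Measured so far in a functional assay on BGC-823 cells (Homo sapiens) for antiproliferative activity, read by MTT assay, tested at 1 uM; a lower number here means a weaker effect, a higher number a stronger effect of the compound at the concentration tested:
compound 1 `COc1cc(C(=O)N/N=C/c2ccc(C(F)(F)F)cc2)cc(OC)c1OC` gives 47.4%
compound 2 `COc1cc(C(=O)N/N=C/c2c(Cl)cccc2Cl)cc(OC)c1OC` gives 0.9%
compound 3 `COc1cc(C2=NN(C(C)=O)C(c3cccc(F)c3)O2)cc(OC)c1OC` gives 14.7%

Compound 2 stands lowest of the three numbers. Compound 3, built on a different core, is the nearest to it, and its number lies higher by more than the usual scatter; compound 1 is the furthest, higher by a margin well beyond the scatter. Compound 4 `COc1cc(C(=O)N/N=C/c2ccc(Cl)c(Cl)c2)cc(OC)c1OC` has not yet been tested in this assay. It differs from compound 2 in one place: 3,4-dichlorophenyl in place of 2,6-dichlorophenyl on a carbon with a double bond to nitrogen. The same atoms are joined differently, so only the placement of the two chlorines on the ring changes. Among the compounds with values here, no measured pair here differs in a single place, so the size of this step has no direct precedent. Compound 1, with a single trifluoromethyl on its ring, shows that this hydrazone core can reach a substantial inhibition, whereas compound 2 is close to inactive. An upward step beyond the scatter is expected, though with wide uncertainty. For compound 4 an inhibition of 30% is expected, within 5% to 55%. The step of a number 29.1 percentage points higher from compound 2 to compound 4 (beyond the scatter) that this estimate implies is upward and beyond the scatter.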

Compound 4, a percentage reported as inhibition, at one concentration (the size of the read-out at that concentration, not a potency): 29.6%
Beside the measured number, compound 4's estimate is 0.4 percentage points above it; measured number inside the range.
By their numbers in this assay, from the lowest: compound 2; then compound 3; then compound 4; then compound 1.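

In this assay, within the data shown here, moving the two chlorines from 2,6-dichlorophenyl to 3,4-dichlorophenyl on the carbon with a double bond to nitrogen gives a number 28.7 percentage points higher from compound 2 to compound 4 (beyond the scatter), the first single-place step. The heavy-atom, donor and acceptor counts of the group stay the same, so this position responds to the placement of the chlorines alone, and the near-absent inhibition of compound 2 does not extend to every dichlorophenyl on the shared core. Nothing at hand bears on the origin of this step.

Going by these compounds, whether the step depends on one chlorine or on both stays open, as does the response of this position to groups other than halogens, such as a methoxy, an amine or a carboxylic acid. On these data alone, whether the same change in placement would carry over to the core of compound 3 also remains open.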